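The compounds below may be only part of what the source reports. "The series", "measured", "known", "first", "only" and "open" are said of these compounds alone.

Measured so far in an ADME assay on MDBK cells (Bos taurus) for cytotoxicity, read by MTT assay, with a stated time of 96 h; on this read-out higher numbers stand for lower toxicity in this test and lower numbers for higher toxicity in this test:

Compound 1 `c1ccc(/N=N/N2CCN(c3ccccc3)CC2)cc1`: > 100000 nM, a limit of the assay.
Compound 2 `Fc1ccc(F)c(/N=N/Nc2cccc(C(F)(F)F)c2)c1`: > 100000 nM, a limit of the assay.

Compound 2 thus has no exact number, only a limit. All the evidence so far is the limit of > 100000 nM in this assay, at which 2 of the 2 values shown sit. Compound 3 `CN(C)CCCN(/N=N/c1cc(F)ccc1F)c1cccc(C(F)(F)F)c1` is compound 2 with 3-(dimethylamino)propyl in place of hydrogen on a nitrogen on an aromatic ring. Going by the values given here, no measured pair of compounds differs in one place, so the size of this change has no direct precedent here. A moderate move toward lower numbers in this assay, meaning higher toxicity, is nevertheless expected, although compound 3 could also remain at the limit. The expected change is an at least 2.5-fold lower number from compound 2 to compound 3 (0.39 log units; beyond the scatter). For compound 3 the estimated value is 40000 nM. The expected range for compound 3 runs from 10000 nM to 100000 nM.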

Compound 3, half-maximal cytotoxic concentration: > 100000 nM
Compound 3: a limit, no number; the forecaster's own chance of this, stated with the estimate: 35%; middle value at least 2.5-fold (0.39 log units) away from the limit.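

In this assay, going by these compounds alone, compound 2 and compound 3 both stand at a limit, and no step between them can be read. The compounds shown leave open at what concentration any of them turns toxic, and whether 3-(dimethylamino)propyl in place of hydrogen changes that concentration at all.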